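Amide substituent change in a mouse whole-organism assay

This account rests on a few compounds, and the source may have more. Where it says the series, first, only, none or still open, it means among the compounds named here.

Compound 1 `O=C(Cn1c(-c2ccc(Cl)cc2)nc2cccnc21)N1CCCC1` gives 17.9 mg/kg in a functional assay on the whole organism with Mus musculus as the target; a lower number here means that less compound is needed, a higher number that more compound is needed for the effect. Compound 2 `O=C(Cn1c(-c2ccc(Cl)cc2)nc2cccnc21)Nc1cccnc1` gives 100 mg/kg in this assay.

Among the measured compounds shown here, compound 2 needs the higher dose of the two measured compounds; its nearest neighbour is compound 1, and the step of a 5.6-fold higher number from compound 1 to compound 2 (0.75 log units; beyond the scatter) is the only measured step. Compound 3 `CN(C)CCNC(=O)Cn1c(-c2ccc(Cl)cc2)nc2cccnc21` differs from compound 2 by 2-(dimethylamino)ethyl in place of pyridin-3-yl on an amide-type nitrogen. That single step alters the same amide position but removes nothing matching pyridin-3-yl, so it bears only loosely on the change. Compound 3 is therefore expected to give 50 mg/kg, with a range of 15 mg/kg to 150 mg/kg. The expected step is a 2.0-fold lower number from compound 2 to compound 3 (0.30 log units; within the scatter), toward a somewhat lower dose.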

Compound 3, dose for half-maximal effect: 62 mg/kg
The estimate for compound 3 lay 1.2-fold (0.09 log units) below the measured number; the measured number falls inside the stated range.
By their numbers in this assay, from the lowest: compound 1; then compounds 3 and 2 (each within the scatter of the next).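

In this assay, 2-(dimethylamino)ethyl in place of pyridin-3-yl on the amide-type nitrogen gives a 1.6-fold lower number from compound 2 to compound 3 (0.21 log units; within the scatter), so this open chain without a ring cannot be told apart from the aromatic ring at this position. Compound 1 still stands apart, with a 3.5-fold higher number from compound 1 to compound 3 (0.54 log units; beyond the scatter), and so far neither group on the amide-type nitrogen reaches the pyrrolidin-1-yl amide. No evidence is available to explain these results. On these data alone, it remains open whether a piperidine or morpholine amide would stay close to compound 1, and whether a longer chain ending in an amine would differ from compound 3.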